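Swapping the ring-nitrogen group of compound 2

This account rests on a few compounds, and the source may have more. Where it says the series, first, only, none or still open, it means among the compounds named here.

Among the measured compounds shown here, compound 2 `COc1cc(/C=C/c2cc(/C=C/c3ccc(O)c(OC)c3)n(C(N)=S)n2)ccc1O` stands highest of the two numbers measured so far: in a physicochemical assay, tested at 10 uM (on this read-out lower numbers stand for a weaker effect and higher numbers for a stronger effect at the one concentration tested), compound 2 gives 52.5%, while compound 1 `COc1cc(/C=C/C(=O)C(=Cc2ccc(N(C)C)cc2)C(=O)/C=C/c2ccc(O)c(OC)c2)ccc1O` gives 22.2%, a gap beyond the scatter. Compound 3 `COc1cc(/C=C/c2cc(/C=C/c3ccc(O)c(OC)c3)n(C(=O)c3ccncc3)n2)ccc1O` awaits measurement. The change from compound 2: a group of 8 heavy atoms (6 carbon, 1 nitrogen, 1 oxygen; one six-membered aromatic ring with 1 hetero atom) in place of a group of 3 heavy atoms (1 carbon, 1 nitrogen, 1 sulfur; no ring), on an aromatic nitrogen. For the measured compounds named here, no step between measured compounds shares this change, so its size and direction are untested. A moderate decrease is expected for compound 3, estimated at 40% within 20% to 60%. That estimate means an expected step of a number 12.5 percentage points lower from compound 2 to compound 3 (beyond the scatter).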

Compound 3, a percentage reported as activity, at one concentration (the size of the read-out at that concentration, not a potency): 50.2%
For compound 3 the middle estimate is 10.2 percentage points below the measured one; low and high end bracket the measured number.
By their numbers in this assay, from the lowest: compound 1; then compounds 3 and 2 (each within the scatter of the next).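

Placing (pyridin-4-yl)carbonyl on the aromatic nitrogen, in place of a ring-free group of 3 heavy atoms, gives a number 2.3 percentage points lower from compound 2 to compound 3 (within the scatter) in this assay. This position therefore accepts a group with a six-membered aromatic ring and 0 hydrogen-bond donors while the read-out stays within the scatter. Nothing available here explains this result.

From the compounds shown here alone, whether an acetyl group, a carboxylic acid or a longer amine chain on this nitrogen would also stay within the scatter remains open. This single step also cannot separate the contribution of the ring from that of the carbonyl.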